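The source may report more compounds than this note shows. Statements on the series, on what has been measured and on what is new or still open speak of the compounds shown alone.

Measured so far:
compound 1 `O=C(O)CCCc1ccc(Cn2cc(Br)c(=O)[nH]c2=O)cc1`, 293000 nM in an assay on isolated protein for inhibition of Thymidylate kinase (Homo sapiens); on this read-out lower numbers stand for stronger inhibition and higher numbers for weaker inhibition
compound 2 `O=C(O)CCCCc1ccc(Cn2cc(Cl)c(=O)[nH]c2=O)cc1`, 122000 nM in this assay

Among the compounds with values here, compound 1 gives the highest of the two numbers in this assay; compound 2 lies lower, beyond the scatter, but the two differ in more than one place, so no single step is read from that pair.

Compound 3 `O=C(O)CCCCCc1ccc(Cn2cc(Br)c(=O)[nH]c2=O)cc1` differs from compound 1 by 2-carboxyethyl in place of carboxy on a saturated chain carbon, three bonds along the chain from an aromatic carbon. Within the data shown here, no measured pair isolates this change. A modest lowering of the number is expected, on the order of a 2.0-fold lower number from compound 1 to compound 3 (0.29 log units; within the scatter), though the evidence for its direction is thin. Compound 3 is estimated at 150000 nM in this assay, within 50000 nM to 450000 nM.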

Compound 3, inhibition constant: 92000 nM
Estimate against measurement, compound 3: 1.6-fold (0.21 log units) above; low and high end bracket the measured number.
By their numbers in this assay, from the lowest: compounds 3 and 2 (each within the scatter of the next); then compound 1.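

In this assay, within the data shown here, the 2-carboxyethyl in place of carboxy, on a saturated chain carbon, three bonds along the chain from an aromatic carbon, gives a 3.2-fold lower number from compound 1 to compound 3 (0.50 log units; beyond the scatter) and is the only step that can be read at a single place. This position therefore accepts a longer acid-bearing chain without a rise in the number, and the lowering lies beyond the scatter. Nothing available bears on the reason for this step.

On these data alone, whether a still longer chain lowers the number further remains open. So does whether an amine or an amide at the chain end would serve in place of the carboxylic acid.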